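Acetyl removed from the ring nitrogen of compound 1

The source may report more compounds than this note shows. Statements on the series, on what has been measured and on what is new or still open speak of the compounds shown alone.

Of the compounds shown here, two have been measured in an assay on HEK293 cells for inhibition of acid ceramidase (Homo sapiens), read by fluorescence, with stated times of 10 min and 3 h (on this read-out higher numbers stand for weaker inhibition and lower numbers for stronger inhibition), so far. Compound 1, `CC(=O)N1CCc2oc(=O)n(C(=O)NCCCCc3ccccc3)c2C1`, gives 293 nM in this assay. Compound 2, `CC(C)CNC(=O)n1c(=O)oc2ccc(C3CCN(C)CC3)cc21`, gives 295 nM in this assay. Compound 1 holds the lower of the two numbers, but the two values lie within the scatter of each other, so nothing separates them.

Compound 3, `O=C(NCCCCc1ccccc1)n1c2c(oc1=O)CCNC2`, has not yet been measured. It differs from compound 1 in one place: hydrogen in place of acetyl on an amine nitrogen in a ring. Among the measured compounds shown here, no measured pair among the two compounds shows what such a change does.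

In the absence of a comparable step, compound 3 is expected to land near compound 1, with a step of a 1.5-fold higher number from compound 1 to compound 3 (0.19 log units; within the scatter) that may reach slightly beyond the scatter toward weaker inhibition. Compound 3 is thus estimated at 450 nM, within the range 120 nM to 1700 nM.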

Compound 3, half-maximal inhibitory concentration: 247 nM
Compound 3: the middle estimate sits 1.8-fold (0.26 log units) above what was measured; the range from low to high includes it.
By their numbers in this assay, from the lowest: compounds 3, 1 and 2 (each within the scatter of the next).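

In this assay, replacing acetyl with hydrogen on the amine nitrogen in the six-membered non-aromatic ring gives a 1.2-fold lower number from compound 1 to compound 3 (0.07 log units; within the scatter) and so separates the two compounds by no more than the usual scatter. Among the compounds shown here, this is the first direct comparison at this position, and it shows that the whole acetyl group, with its double bond and hydrogen-bond acceptor, can leave the nitrogen without a change that this read-out can distinguish. Nothing measured here accounts for the two compounds reading alike.

As far as these compounds go, the comparison covers only acetyl and hydrogen on this nitrogen, so it remains open whether a methyl or benzyl group there would give a number beyond the scatter of compound 3. From the compounds shown here alone, it also remains open whether a sulfonamide at this nitrogen would do so.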